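Series notes: pyridin-2-yl in place of 4-(trifluoromethyl)phenyl

The compounds below may be only part of what the source reports. "The series", "measured", "known", "first", "only" and "open" are said of these compounds alone.

Compound 2 `C=C1C[C@]23C[C@@]1(O)CC[C@@H]2c1cccc(C)c1[C@@H]3Cn1cc(-c2ccc(C(F)(F)F)cc2)nn1` carries a 4-(trifluoromethyl)phenyl group on the five-membered aromatic ring with 3 nitrogen, and compound 1 `C=C1C[C@]23C[C@@]1(O)CC[C@@H]2c1cccc(C)c1[C@@H]3Cn1cc(-c2ccccn2)nn1` differs from it by pyridin-2-yl in place of 4-(trifluoromethyl)phenyl on an aromatic carbon. In a functional assay on SW480 cells (Homo sapiens) for cytotoxicity, read by MTT assay, with a stated time of 4 days (a higher number here means a weaker inhibitor, a lower number a stronger inhibitor), compound 2 gives > 20000 nM, which is a limit of the assay and not a number. In this assay compound 1 gives > 20000 nM, again a limit. The step from compound 2 to compound 1 is therefore a step that the two limits leave unreadable from compound 2 to compound 1.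

Compound 3 `C=C1C[C@]23C[C@@]1(O)CC[C@H]2c1ccc(OS(=O)(=O)c2ccc(C)cc2)c(C)c1[C@@H]3Cn1cc(-c2ccc(C(F)(F)F)cc2)nn1` keeps the 4-(trifluoromethyl)phenyl group on a different core; the difference between the core of compound 3 and the core of compound 2 is not broken down here. In this assay compound 3 gives > 20000 nM, a limit. Among the measured compounds shown here, every value measured so far sits at the limit of > 20000 nM in this assay, at which 3 of the 3 values shown sit, so no compound can be ranked against another.

Compound 4 `C=C1C[C@]23C[C@@]1(O)CC[C@H]2c1ccc(OS(=O)(=O)c2ccc(C)cc2)c(C)c1[C@@H]3Cn1cc(-c2ccccn2)nn1` is not yet measured. It differs from compound 3 by pyridin-2-yl in place of 4-(trifluoromethyl)phenyl on an aromatic carbon, the same change, at the same place, as that made from compound 2 to compound 1. The earlier step could not be read, because compound 2 and compound 1 both sit at the limit of > 20000 nM in this assay, at which 3 of the 3 values shown sit. The expected step in this assay is estimated as a step that the limit leaves unreadable from compound 3 to compound 4. This expectation rests on compound 1, which after the same change gives > 20000 nM, a limit. Compound 4 is expected to give 40000 nM, most likely again only as a limit, with a range from 12000 nM to 150000 nM.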

Compound 4, half-maximal inhibitory concentration: > 20000 nM
Compound 4: a limit, no number (the forecaster's own chance of this, stated with the estimate: 85%); the middle value does not contradict the limit.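

In this assay compound 4 gives > 20000 nM, a limit and not a number. No step can be read from compound 3 to compound 4, because both compounds sit at the same limit: the limit of > 20000 nM in this assay, at which 4 of the 4 values shown sit.

The compounds shown leave open whether pyridin-2-yl and 4-(trifluoromethyl)phenyl differ at all in this assay, and whether either core can give a measurable value there.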